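This account rests on a few compounds, and the source may have more. Where it says the series, first, only, none or still open, it means among the compounds named here.

Compound 2 `COc1ccc(NS(=O)(=O)/C=C/c2c(OC)cc(OC)cc2OC)cc1` and compound 1 `COc1cc(OC)c(/C=C/S(=O)(=O)Nc2ccc(OC)nc2)c(OC)c1` share a core and differ only in the group on the sulfonamide nitrogen. For the measured compounds named here, in a functional assay on HCT-116 cells (Homo sapiens) for antiproliferative activity, read by MTT assay, with a stated time of 72 h (a lower number here means a stronger inhibitor of growth, a higher number a weaker inhibitor of growth), compound 2 gives 10 nM, the lowest of the two numbers known here, and compound 1 gives 1000 nM; the only measured step, a 100-fold lower number from compound 1 to compound 2 (2.00 log units; beyond the scatter), is large and beyond the scatter. Compound 3 `COc1cc(OC)c(/C=C/S(=O)(=O)Nc2cnc(Cl)cn2)c(OC)c1` is not yet measured and differs from compound 2 by 5-chloropyrazin-2-yl in place of 4-methoxyphenyl on a sulfonamide nitrogen. Going by the values given here, the one step that bears on this change runs in the opposite direction, from an aromatic ring with a nitrogen to a ring of carbon only, and lowered the number strongly. Going back to a ring with two nitrogens is therefore expected to raise the number, although the new group is not the same as in compound 1, so the size is uncertain. Compound 3 is estimated at 200 nM, within 20 nM to 2000 nM, a step of a 20-fold higher number from compound 2 to compound 3 (1.30 log units; beyond the scatter).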

Compound 3, concentration for 50% growth inhibition: > 10000 nM
Compound 3: no number, only a limit (the forecaster's own chance of this, stated with the estimate: 5%); at least 50-fold (1.69 log units) between middle value and limit.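

The value for compound 3 is a limit of the assay, not a number: the limit of > 10000 nM in this assay, at which 1 of the 3 values shown sits.

For the compounds shown here, the earlier pair showed only that one ring with a nitrogen on the sulfonamide nitrogen gave a higher number than 4-methoxyphenyl. The 5-chloropyrazin-2-yl group now gives an at least 1000-fold higher number from compound 2 to compound 3 (3.00 log units; beyond the scatter), and the loss goes further than that of 6-methoxypyridin-3-yl, with an at least 10-fold higher number from compound 1 to compound 3 (1.00 log units; beyond the scatter). Across these three compounds, both rings with ring nitrogens sit on the weaker side of 4-methoxyphenyl, and no compound shown goes against this.

Compound 3 changes the ring and its substituent together, chlorine replacing methoxy, so the two effects cannot be separated here. Going by these compounds, a 4-chlorophenyl group on the sulfonamide nitrogen would test chlorine on a ring of carbon only, and how it would fare remains open.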